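Notes on the ring-nitrogen substituent, compounds 1 to 3

A few compounds are considered here, and "the series" means these few. Any claim that something is new, unique, unknown or untested is made for them only; others in the source may bear on it.

Measured so far in a functional assay on CHO cells with adenosine receptor A1 (Homo sapiens) as the target, read by cAMP accumulation and immunoassay, with a stated time of 6 min, tested at 0.01 uM; a higher number here means a weaker effect of the compound at the concentration tested, a lower number a stronger effect:
compound 1, `CC(C)N1CCN(Cc2csc(N)c2C(=O)c2ccc(Cl)cc2)CC1`: compound 1 gives -1%
compound 2, `Nc1scc(CN2CCN(C3CCCCCC3)CC2)c1C(=O)c1ccc(Cl)cc1`: compound 2 gives 2.9%

Compound 2 holds the highest of the two numbers, but its nearest neighbour is compound 1 and the step of a number 3.9 percentage points higher from compound 1 to compound 2 (within the scatter) lies within the scatter, so the two cannot be ordered. Compound 3, `Nc1scc(CN2CCN(c3ccc(F)c(F)c3)CC2)c1C(=O)c1ccc(Cl)cc1`, carries the change (3,4-difluorophenyl in place of cycloheptyl on an amine nitrogen in a ring). Going by the values given here, the only measured step, a number 3.9 percentage points higher from compound 1 to compound 2 (within the scatter), swaps one non-aromatic group for another on the same ring nitrogen and stayed within the scatter; no measured step brings an aromatic group to that position, so nothing measured bears directly on this change. With both known values close to zero, compound 3 is expected to give 4%, with a range of -14% to 26%. The expected step is a number 1.1 percentage points higher from compound 2 to compound 3 (within the scatter), nothing beyond the scatter.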

Compound 3, a percentage reported as activity, at one concentration (the size of the read-out at that concentration, not a potency): -3.2%
Estimate against measurement, compound 3: 7.2 percentage points above; measured number inside the range.
By their numbers in this assay, from the lowest: compounds 3, 1 and 2 (each within the scatter of the next).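

Going by these compounds alone, compound 3 puts an aromatic group on the amine nitrogen in the ring for the first time, and in this assay the exchange for cycloheptyl comes to a number 6.1 percentage points lower from compound 2 to compound 3 (within the scatter), while the exchange for isopropyl comes to a number 2.2 percentage points lower from compound 1 to compound 3 (within the scatter). Within the data shown here, the position has now carried isopropyl, cycloheptyl and 3,4-difluorophenyl, non-aromatic and aromatic groups alike, with no step leaving the scatter, so the three compounds cannot be ordered at this single concentration. No data beyond these numbers bear on the result.

Going by these compounds, it remains open whether any group on this nitrogen can move the number beyond the scatter, for instance a carboxylic acid on a longer chain or a primary amine. On these data alone, how these compounds compare at other concentrations also remains open.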